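A few compounds are considered here, and "the series" means these few. Any claim that something is new, unique, unknown or untested is made for them only; others in the source may bear on it.

Measured so far in an ADME assay on HEK293 cells (Homo sapiens) for antiproliferative activity, read by MTT assay, with a stated time of 24 h; on this read-out lower numbers stand for stronger inhibition and higher numbers for weaker inhibition:
compound 1 `COc1ccc(-c2cc(C(=O)/C=C/c3ccc(C)cc3)nc3cc(-c4ccccc4)nn23)cc1OC`: 57400 nM
compound 2 `COc1ccc(-c2cc(/C=C/C(=O)c3ccc(C)c(C)c3)nc3cc(-c4ccccc4)nn23)cc1OC`: 46200 nM
compound 3 `COc1ccc(-c2cc(/C=C/C(=O)c3ccccc3)nc3cc(-c4ccccc4)nn23)cc1OC`: 51200 nM

Compound 1 carries the highest of the three numbers in this assay, but the steps of a 1.1-fold lower number from compound 1 to compound 3 (0.05 log units; within the scatter) and a 1.2-fold lower number from compound 1 to compound 2 (0.09 log units; within the scatter) are both within the scatter, as is a 1.1-fold higher number from compound 2 to compound 3 (0.04 log units; within the scatter). Compound 4 `COc1cc(-c2cc(C(=O)/C=C/c3ccc(C)cc3)nc3cc(-c4ccccc4)nn23)cc(OC)c1OC` differs from compound 1 by methoxy in place of hydrogen on an aromatic carbon. Among the measured compounds shown here, the three measured steps all concern the carbonyl-bearing side of the shared core; none touches the 3,4-dimethoxyphenyl ring, so no measured step bears directly on this change. With every measured number within the scatter of the others, no step beyond the scatter is expected in this assay. Compound 4 is therefore estimated at 55000 nM, with a range of 25000 nM to 120000 nM. The expected step is a 1.0-fold lower number from compound 1 to compound 4 (0.02 log units; within the scatter).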

Compound 4, half-maximal inhibitory concentration: 56100 nM
For compound 4 the middle estimate is 1.0-fold (0.01 log units) below the measured one; the range from low to high includes it.
By their numbers in this assay, from the lowest: compounds 2, 3, 4 and 1 (each within the scatter of the next).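

Among the compounds shown here, the change from 3,4-dimethoxyphenyl to 3,4,5-trimethoxyphenyl is the first change on this ring to be read in this assay (a 1.0-fold lower number from compound 1 to compound 4 (0.01 log units; within the scatter)). Methoxy in place of hydrogen at this aromatic carbon therefore stays within the scatter in the setting of compound 1. Nothing measured here offers an explanation for this result.

Still open, going by these compounds, is whether a hydroxy group or an amine at this carbon would behave as methoxy does. Also open, on these data alone, is whether the same methoxy gives a similar result with the 2-benzoylethenyl group of compound 3.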